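The compounds below may be only part of what the source reports. "The series", "measured", "known", "first", "only" and "open" are said of these compounds alone.

Three compounds share one core and differ only in the aromatic group attached to an aromatic nitrogen of the five-membered ring. Compound 1 `COc1cc(/C=C/C(C)=O)ccc1OCc1cn(-c2c(F)cccc2F)nn1` carries a 2,6-difluorophenyl there; compound 2 `COc1cccc(-n2cc(COc3ccc(/C=C/C(C)=O)cc3OC)nn2)c1` carries a 3-methoxyphenyl; compound 3 `COc1cc(/C=C/C(C)=O)ccc1OCc1cn(-c2ccc(C=O)cc2)nn1` carries a 4-formylphenyl. In a functional assay on MCF7 cells (Homo sapiens) for antiproliferative activity, read by MTT assay, with a stated time of 48 h (on this read-out lower numbers stand for stronger inhibition and higher numbers for weaker inhibition), compound 1 gives 2030 nM, compound 2 gives 1800 nM and compound 3 gives 86400 nM. Among these three numbers compound 1 stands second highest: the step of a 1.1-fold lower number from compound 1 to compound 2 (0.05 log units; within the scatter) lies within the scatter, while the step of a 43-fold higher number from compound 1 to compound 3 (1.63 log units; beyond the scatter) is large, as is the step of a 48-fold higher number from compound 2 to compound 3 (1.68 log units; beyond the scatter).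

Compound 4 `COc1cc(/C=C/C(C)=O)ccc1OCc1cn(-c2cc(F)cc(Br)c2)nn1` has not yet been measured. It differs from compound 1 in one place: 3-bromo-5-fluorophenyl in place of 2,6-difluorophenyl on an aromatic nitrogen. Both earlier steps bear on this change, since each also swaps the aromatic group on that nitrogen. The swap to 3-methoxyphenyl moved nothing beyond the scatter, whereas the swap to 4-formylphenyl weakened inhibition strongly; compound 4 keeps a phenyl bearing halogens, more like compound 1 than like compound 3, so no step beyond the scatter is expected in this assay. Compound 4 is therefore estimated at 2200 nM, with a likely range from 700 nM to 7000 nM, which means an expected step of a 1.1-fold higher number from compound 1 to compound 4 (0.03 log units; within the scatter).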

Compound 4, half-maximal inhibitory concentration: 65500 nM
Estimate against measurement, compound 4: 30-fold (1.47 log units) below; the whole stated range lies below it.
By their numbers in this assay, from the lowest: compounds 2 and 1 (each within the scatter of the next); then compounds 4 and 3 (each within the scatter of the next).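

In this assay, this position proves far less forgiving than compounds 1 and 2 suggested: the change to 3-bromo-5-fluorophenyl brings a large shift (a 32-fold higher number from compound 1 to compound 4 (1.51 log units; beyond the scatter)) and an equally clear one against the 3-methoxyphenyl of compound 2 (a 36-fold higher number from compound 2 to compound 4 (1.56 log units; beyond the scatter)), even though the entering and leaving groups both count 8 heavy atoms and neither has a hydrogen-bond donor or acceptor. Halogens on the phenyl therefore do not by themselves keep the number low, and compound 4 instead falls alongside the 4-formylphenyl of compound 3 (a 1.3-fold lower number from compound 3 to compound 4 (0.12 log units; within the scatter)), so two quite different groups end up together at the weak end of this small set. Nothing shown here gives a measured reason for this loss.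

The compounds shown leave open whether the bromine or the changed placement of the halogens on the phenyl matters more, as the two differ together here. A 3,5-difluorophenyl would help separate those two, and a phenyl bearing an amine or a carboxylic acid would test this position with groups of another kind.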